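Selenium-bearing Thiadiazoles: Methoxy Replacing Bromo on the Phenyl Ring

A few compounds are considered here, and "the series" means these few. Any claim that something is new, unique, unknown or untested is made for them only; others in the source may bear on it.

Measured compounds:
- compound 1, `Cc1ccccc1-c1nnc(-n2[se]c3ccccc3c2=O)s1`, 19400 nM
- compound 2, `Cc1cccc(-c2nnc(-n3[se]c4ccccc4c3=O)s2)c1`, 17800 nM
- compound 3, `O=c1c2ccccc2[se]n1-c1nnc(-c2ccccc2Br)s1`, 27400 nM

All three share one core and differ only in the substituent on the phenyl ring. In a functional assay on SSMC-7721 cells (Homo sapiens) for antiproliferative activity, read by CCK-8 assay, with a stated time of 48 h (on this read-out lower numbers stand for stronger inhibition and higher numbers for weaker inhibition), compound 3 gives the highest of the three numbers, yet both its neighbours lie within the scatter: a 1.4-fold higher number from compound 1 to compound 3 (0.15 log units; within the scatter) and a 1.5-fold higher number from compound 2 to compound 3 (0.19 log units; within the scatter). The step of a 1.1-fold lower number from compound 1 to compound 2 (0.04 log units; within the scatter) likewise stays within the scatter, so the three numbers together describe one level rather than an order.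

Compound 4, `COc1ccccc1-c1nnc(-n2[se]c3ccccc3c2=O)s1`, is not yet measured. It differs from compound 3 by methoxy in place of bromo on an aromatic carbon. Among the compounds with values here, the step that bears most directly on this change is the one from compound 1 to compound 3, in which bromo replaced methyl at the same aromatic carbon without a shift beyond the scatter; the move of methyl from one position to another in the step from compound 1 to compound 2 was equally quiet. With nothing in these data showing that a change at this carbon moves this assay, no step beyond the scatter is expected in this assay for compound 4, that is, an expected step of a 1.3-fold lower number from compound 3 to compound 4 (0.12 log units; within the scatter).

Compound 4 is therefore estimated at 21000 nM, with a range from 9000 nM to 50000 nM.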

Compound 4, half-maximal inhibitory concentration: 14300 nM
Beside the measured number, compound 4's estimate is 1.5-fold (0.17 log units) above it, within the range that was stated.
By their numbers in this assay, from the lowest: compounds 4, 2, 1 and 3 (each within the scatter of the next).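

In this assay, the same aromatic carbon now carries a third group, and methoxy, the only one of the three that brings an oxygen and a hydrogen-bond acceptor, stays within the scatter of both groups it can be set against: a 1.9-fold lower number from compound 3 to compound 4 (0.28 log units; within the scatter) for the exchange with bromo, and a 1.4-fold lower number from compound 1 to compound 4 (0.13 log units; within the scatter) for the exchange with methyl. The earlier compounds showed this quiet behaviour only for methyl and bromo, so it now extends to a group with an oxygen; the exchange with bromo is the largest of the steps among these compounds, yet it remains within the scatter and gives no order among the three groups. No measurement is available that would bear on how these groups act at this carbon.

The compounds shown leave open whether an amine, a carboxylic acid or a longer chain such as ethoxy at this carbon would shift the number beyond the scatter. They also leave open whether methoxy would stay as quiet at the other ring carbon where compound 2 carries its methyl.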